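The compounds below may be only part of what the source reports. "The series", "measured", "known", "first", "only" and "open" are said of these compounds alone.

Measured compounds:
- compound 1 `O=C(CN1C(=O)c2ccccc2C1=O)NN1C(=O)CSC1c1c(F)cccc1Cl`: 3.79
- compound 2 `CN(C)c1ccc(C2SCC(=O)N2NC(=O)CN2C(=O)c3ccccc3C2=O)cc1`: 2.84
- compound 3 `O=C(CN1C(=O)c2ccccc2C1=O)NN1C(=O)CSC1c1ccccc1`: 2.23

In a physicochemical assay for lipophilicity, in phosphate buffer, measured as octanol-water partition, with a stated time of 24 h (a lower number here means a more polar compound, a higher number a more lipophilic compound), compound 1 stands highest of the three. The nearest is compound 2, reached by a number 0.95 log units lower from compound 1 to compound 2 (beyond the scatter), and the furthest is compound 3, reached by a number 1.56 log units lower from compound 1 to compound 3 (beyond the scatter). Between the two lower compounds the gap is a number 0.61 log units lower from compound 2 to compound 3 (beyond the scatter).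

Compound 4 `O=C(CN1C(=O)c2ccccc2C1=O)NN1C(=O)CSC1c1ccc(Cl)cc1Cl` is not yet measured. It differs from compound 1 in one place: 2,4-dichlorophenyl in place of 2-chloro-6-fluorophenyl on a saturated ring carbon.

The measured steps that bear on this change are those that swap the group on the same saturated ring carbon. Removing both halogens, as in compound 3, gave a large drop in this assay; replacing the halogenated ring with the 4-(dimethylamino)phenyl of compound 2 gave a modest drop. Neither step exchanges one halogen for another, so the data give no direct read on the fluorine-to-chlorine swap. Since compound 4 keeps a ring with two halogens, its value is expected to stay close to compound 1, with the estimated step of a number 0.31 log units higher from compound 1 to compound 4 (beyond the scatter) lying near the edge of the scatter. The estimate for compound 4 in this assay is 4.1, between 3.6 and 4.6.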

Compound 4, partition coefficient: 2.54
Compound 4: the middle estimate sits 1.56 log units above what was measured; the whole stated range lies above it.
By their numbers in this assay, from the lowest: compound 3; then compounds 4 and 2 (each within the scatter of the next); then compound 1.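

In this assay, a ring with two halogens on this saturated ring carbon did not by itself preserve the number of compound 1: the change to 2,4-dichlorophenyl gave a number 1.25 log units lower from compound 1 to compound 4 (beyond the scatter), so the value depends on which dihalogenated ring is present, not merely on there being two halogens. The same ring gave only a number 0.31 log units higher from compound 3 to compound 4 (beyond the scatter), while the comparison with the 4-(dimethylamino)phenyl ring gave a number 0.30 log units lower from compound 2 to compound 4 (within the scatter), so these two differently substituted rings cannot be told apart here. Nothing available explains why the two halogenated rings differ so strongly in this measurement.

The compounds shown leave open whether the step from compound 1 to compound 4 follows from the loss of fluorine, the gain of the second chlorine or the different arrangement of the halogens on the ring, since all of these changes coincide in this one pair. Phenyl rings bearing a single chlorine or a single fluorine would help separate these contributions, and a methoxy group or a carboxylic acid on the ring would show how far the trend extends beyond halogens and the dimethylamino group.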